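Swapping the aryl amide of compound 3 for a thiazole

The source may hold more compounds than are shown below. What is called first, only, known or untested is meant among the compounds shown, and "the series" means these compounds.

Measured compounds:
compound 1, `CC(=O)c1ccc(OCC(=O)Nc2cccc(NC(=O)c3ccc(N(C)C)cc3)c2)cc1F`, 445 nM
compound 2, `O=C(COc1ccc2c(=O)ccoc2c1)Nc1cccc(NC(=O)c2ccc(F)cc2)c1`, 129 nM
compound 3, `CCOc1ccc(C(=O)Nc2cccc(NC(=O)COc3ccc4c(=O)ccoc4c3)c2)cc1`, 17 nM

In an assay on isolated protein for inhibition of Rho-associated protein kinase 1 (Homo sapiens), read by scintillation counting, radiometric assay and 33P incorporation, with a stated time of 40 min, in the presence of a further agent that is not named here (on this read-out lower numbers stand for stronger inhibition and higher numbers for weaker inhibition), compound 3 gives the lowest number of the three, and its nearest neighbour is compound 2, while compound 1 lies furthest away. For the measured compounds named here, the one measured step between compounds that differ in a single place is a 7.6-fold lower number from compound 2 to compound 3 (0.88 log units; beyond the scatter), which shows that the group on the far end of the benzamide matters for this read-out.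

Compound 4, `O=C(COc1ccc2c(=O)ccoc2c1)Nc1cccc(NC(=O)c2cnc(C(F)(F)F)s2)c1`, is not yet measured. It differs from compound 3 in one place: 2-(trifluoromethyl)-1,3-thiazol-5-yl in place of 4-ethoxyphenyl on a carbonyl carbon. Going by the values given here, no measured step bears directly on this swap, since the single step available exchanges one substituent on a six-membered ring for another rather than replacing the whole ring. Among the compounds with values here, the change is therefore larger than anything yet tested, and the only guidance is that compound 3 already gives the lowest number seen, which leaves more room to move up than down. A somewhat higher number in this assay is expected for compound 4, about a 4.7-fold higher number from compound 3 to compound 4 (0.67 log units; beyond the scatter). The estimate for compound 4 is 80 nM, within a range from 20 nM to 400 nM.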

Compound 4, half-maximal inhibitory concentration: 160 nM
The estimate for compound 4 lay 2.0-fold (0.30 log units) below the measured number; low and high end bracket the measured number.
By their numbers in this assay, from the lowest: compound 3; then compounds 2 and 4 (each within the scatter of the next); then compound 1.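

For the compounds shown here, compound 4 is the first case here in which the whole ring on the carbonyl carbon changes, not just a substituent on it, and in this assay the result is a 9.4-fold higher number from compound 3 to compound 4 (0.97 log units; beyond the scatter) with a five-membered aromatic ring in place of the 4-ethoxyphenyl group. Set against the 4-fluorophenyl group of compound 2, the 2-(trifluoromethyl)-1,3-thiazol-5-yl group gives a 1.2-fold higher number from compound 2 to compound 4 (0.09 log units; within the scatter) and so cannot be told apart from it, which leaves 4-ethoxyphenyl as the one group of these three that stands apart at this position. Nothing measured here offers a reason for either step.

In compound 4 the ring and its substituent change together, so the compounds shown cannot say which of the two accounts for the step from compound 3. A phenyl ring carrying trifluoromethyl or a thiazole carrying ethoxy would separate these two changes, while a longer chain such as propoxy or an amine on the ring would test how far the gain seen with ethoxy extends.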